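The source may hold more compounds than are shown below. What is called first, only, known or untested is meant among the compounds shown, and "the series" means these compounds.

Measured in a functional assay on MV4-11 cells (Homo sapiens) for inhibition, read by resazurin assay, with a stated time of 72 h; a lower number here means a stronger inhibitor of growth, a higher number a weaker inhibitor of growth:
Compound 1 `COc1ccc(Nc2nccc(-c3sc(SC)nc3C)n2)c(OC)c1`: 530 nM
Compound 2 `COCCSc1nc(C)c(-c2ccnc(Nc3ccc(OC)cc3OC)n2)s1`: 810 nM
Compound 3 `COc1ccc(Nc2nccc(-c3sc(N(C)C)nc3C)n2)c(OC)c1`: 170 nM

Among these, compound 3 has the lowest number, 170 nM, and so is the strongest growth inhibitor of the set. Its steps to both other compounds lie beyond the scatter. Compound 4 `CCCSc1nc(C)c(-c2ccnc(Nc3ccc(OC)cc3OC)n2)s1` has not yet been measured. It carries propylsulfanyl in place of dimethylamino on an aromatic carbon of the five-membered aromatic ring with 1 nitrogen and 1 sulfur (propylsulfanyl in place of dimethylamino on an aromatic carbon).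

Among the compounds with values here, two measured steps bear most directly on this exchange, though they run in the opposite direction. Replacing methylsulfanyl with dimethylamino gave a 3.1-fold lower number from compound 1 to compound 3 (0.49 log units; beyond the scatter), and replacing (2-methoxyethyl)sulfanyl with dimethylamino gave a 4.8-fold lower number from compound 2 to compound 3 (0.68 log units; beyond the scatter). Changing the chain on sulfur, by contrast, gave only a 1.5-fold higher number from compound 1 to compound 2 (0.18 log units; within the scatter). Compound 4 goes back from dimethylamino to a chain on sulfur, so a modest rise in the number is expected in this assay, of about the size of those two steps. Within the data shown here, no measured compound carries propylsulfanyl, so this expectation rests on its two nearest relatives alone. The expected change is a 3.5-fold higher number from compound 3 to compound 4 (0.55 log units; beyond the scatter). Compound 4 is estimated at 600 nM, with an expected range from 270 nM to 1300 nM.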

Compound 4, concentration for 50% growth inhibition: 2240 nM
The estimate for compound 4 lay 3.7-fold (0.57 log units) below the measured number; the measured number lies above the stated range.
By their numbers in this assay, from the lowest: compound 3; then compounds 1 and 2 (each within the scatter of the next); then compound 4.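

In this assay, within the data shown here, putting propylsulfanyl in place of dimethylamino on this aromatic carbon gives a 13-fold higher number from compound 3 to compound 4 (1.12 log units; beyond the scatter) and so is a larger step than any seen among the earlier compounds, which shows that the choice of group at this position can matter more than those compounds suggested. The chain on sulfur also counts, although the earlier step between a methylsulfanyl and a (2-methoxyethyl)sulfanyl group stayed within the scatter: ethyl in place of hydrogen on the chain gives a 4.2-fold higher number from compound 1 to compound 4 (0.63 log units; beyond the scatter) on the way to propylsulfanyl, and methyl in place of methoxy gives a 2.8-fold higher number from compound 2 to compound 4 (0.44 log units; beyond the scatter) for a small change at the chain's far end. Chain length alone therefore does not order these sulfur compounds, since compound 2, with the longest chain, does not have the highest number, and the methoxy group's oxygen marks the difference between compound 2 and compound 4.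

As far as these compounds go, it remains open whether other amines, such as pyrrolidine or morpholine, would match dimethylamino, and whether a propoxy or plain propyl group would behave like propylsulfanyl. Nothing shown here explains why these steps differ in size.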